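The compounds below may be only part of what the source reports. "The series", "measured", "known", "first", "only" and "open" are said of these compounds alone.

Going by the values given here, compound 2 `O=C(CCC(=O)c1ccccc1)Nc1nc2ccc(F)cc2s1` is measured in a functional assay on the whole organism with Mus musculus as the target, in the maximal electroshock model, with a stated time of 4 h (on this read-out lower numbers stand for an effect already at smaller amounts and higher numbers for an effect only at larger amounts of compound), where compound 2 gives 300 mg/kg, level with compound 1 `O=C(CCC(=O)c1ccccc1)Nc1nc2ccc(Cl)cc2s1`, which in this assay gives 300 mg/kg; the single step of no change at the digits printed from compound 1 to compound 2 (within the scatter) lies within the scatter. Compound 3 `O=C(CCC(=O)c1ccccc1)Nc1nc2cc(Cl)c(F)cc2s1` differs from compound 2 by chloro in place of hydrogen on an aromatic carbon. Among the compounds with values here, no measured step adds a chloro group to a carbon bearing hydrogen, so the only guide is that swapping halogens left the read-out unchanged. Compound 3 is therefore expected to show no step beyond the scatter, no change at the digits printed from compound 2 to compound 3 (within the scatter). Compound 3 is estimated at 300 mg/kg, within 150 mg/kg to 600 mg/kg.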

Compound 3, minimum effective dose: 300 mg/kg
For compound 3 middle estimate and measured number coincide at the digits printed; low and high end bracket the measured number.
By their numbers in this assay, from the lowest: compounds 1, 2 and 3 (each within the scatter of the next).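

In this assay the step of no change at the digits printed from compound 2 to compound 3 (within the scatter) shows that chloro can enter in place of hydrogen, ortho to a fluoro group, with the read-out staying level, whereas the earlier pair only exchanged one halogen for another. Going by these compounds alone, this is the first look at this carbon, and it adds a group there rather than swapping one. Nothing measured here offers an explanation of this result. Going by these compounds, whether an amine or a carboxylic acid on this carbon would shift the read-out remains open, as does the effect of a methoxy group there.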